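A few compounds are considered here, and "the series" means these few. Any claim that something is new, unique, unknown or untested is made for them only; others in the source may bear on it.

Working notes on the series, read in a functional assay on DU-145 cells (Homo sapiens) for inhibition, read by trypan blue exclusion, with a stated time of 96 h; a higher number here means a weaker inhibitor of growth, a lower number a stronger inhibitor of growth. Compound 1 `Cc1ccc(S(=O)(=O)/C(=C/c2ccc(O)c([N+](=O)[O-])c2)C(=O)c2ccc(Cl)cc2)cc1` gives 25000 nM and compound 3 `Cc1ccc(CS(=O)(=O)/C(=C/c2ccc(N(C)C)cc2)C(=O)c2ccc(Cl)cc2)cc1` gives 50000 nM, two values within the scatter of each other. Compound 2 `CN(C)c1ccc(/C=C(/SCc2ccccc2Cl)C(=O)c2ccc(Cl)cc2)cc1` returns only a limit of the assay, > 100000 nM.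

Compound 4 `Cc1ccc(S(=O)(=O)/C(=C/c2ccc(N(C)C)cc2)C(=O)c2ccc(Cl)cc2)cc1` has 4-methylphenyl in place of 4-methylbenzyl on a sulfonyl sulfur. Among the measured compounds shown here, no measured pair isolates this change. Compound 1 also has 4-methylphenyl on a sulfonyl sulfur and gives 25000 nM, so no change beyond the scatter is expected in this assay. The expected move, a 1.3-fold lower number from compound 3 to compound 4 (0.10 log units; within the scatter), is small and has no firm direction. The estimate for compound 4 is 40000 nM, with an expected range of 15000 nM to 100000 nM.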

Compound 4, concentration for 50% growth inhibition: > 100000 nM
Compound 4: no number, only a limit; the forecaster's own chance of this, stated with the estimate: 15%; at least 2.5-fold (0.39 log units) between middle value and limit.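

In this assay compound 4 returns only a limit, so 4-methylphenyl in place of 4-methylbenzyl on a sulfonyl sulfur reads as a floor, an at least 2.0-fold higher number from compound 3 to compound 4 (0.30 log units; that floor lies within the scatter), which gives no firm direction. Compound 1 carries the same 4-methylphenyl on sulfonyl, yet 4-(dimethylamino)phenyl in place of 4-hydroxy-3-nitrophenyl gives an at least 4.0-fold higher number from compound 1 to compound 4 (0.60 log units; beyond the scatter), so 4-methylphenyl alone does not keep a measurable value. The step from compound 2 cannot be read, and the top of the series is cut off: the limit of > 100000 nM in this assay, at which 2 of the 4 values shown sit.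

Open, going by these compounds, is how far compound 4 lies past its limit. Also open, on these data alone, is whether a 2-phenylethyl group on the sulfonyl sulfur would read within the assay range.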